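A few compounds are considered here, and "the series" means these few. Any claim that something is new, unique, unknown or untested is made for them only; others in the source may bear on it.

Compound 2 `C#CCn1cc(C(=O)NC(CC(=O)Nc2ccccn2)c2ccccc2)c(=O)c2ccc(Cl)nc21` and compound 1 `C#CCn1cc(C(=O)NC(CC(=O)Nc2ccccc2)c2ccccc2)c(=O)c2cc(F)c(Cl)nc21` sit close together in a functional assay on PA-1 cells (Homo sapiens) for cytotoxicity, read by MTT assay, with a stated time of 72 h; on this read-out lower numbers stand for stronger inhibition and higher numbers for weaker inhibition: compound 2 gives 1700 nM, and compound 1 gives 2100 nM, a gap that lies within the scatter, so neither can be called the more potent. Compound 3 `C#CCn1cc(C(=O)NC(CC(=O)Nc2ccccc2)c2ccccc2)c(=O)c2cccnc21` returns only a limit of this assay, > 10000 nM. That is the limit of > 10000 nM in this assay, at which 1 of the 3 values shown sits. Compound 4 `C#CCn1cc(C(=O)NC(CC(=O)NC2CCCC2)c2ccccc2)c(=O)c2ccc(Cl)nc21` differs from compound 2 by cyclopentyl in place of pyridin-2-yl on an amide-type nitrogen. Within the data shown here, no measured pair covers this change, so the value of compound 2 is the only anchor. Compound 4 is expected to show a small shift, a 1.5-fold higher number from compound 2 to compound 4 (0.17 log units; within the scatter), toward a somewhat higher number. Compound 4 is therefore estimated at 2500 nM, within a range from 900 nM to 7000 nM.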

Compound 4, half-maximal inhibitory concentration: 1100 nM
Beside the measured number, compound 4's estimate is 2.3-fold (0.36 log units) above it; measured number inside the range.
By their numbers in this assay, from the lowest: compounds 4, 2 and 1 (each within the scatter of the next). At a limit, above all of these: compound 3.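

In this assay, cyclopentyl on the amide-type nitrogen gives a 1.5-fold lower number from compound 2 to compound 4 (0.19 log units; within the scatter), so at this position a five-membered carbon ring without a hydrogen-bond acceptor reads the same as pyridin-2-yl within the scatter. The earlier compounds shown here held no pair that tested this nitrogen, and this pair now shows that an aromatic ring is not required there for activity at this level. Nothing shown gives a reason for this step. Still open, going by these compounds, is how this nitrogen responds to a piperidine ring, a longer alkyl chain or a carboxylic acid.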